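A few compounds are considered here, and "the series" means these few. Any claim that something is new, unique, unknown or untested is made for them only; others in the source may bear on it.

The compounds measured in a functional assay on HeLa cells (Homo sapiens) for cytotoxicity, read by MTT assay, with a stated time of 48 h; on this read-out lower numbers stand for stronger inhibition and higher numbers for weaker inhibition:

Compound 1, `O=c1ccoc2cc(OCc3cn(Cc4ccc(Cl)cc4)nn3)ccc12`, gives 37600 nM.
Compound 2, `O=c1ccoc2cc(OCc3cn(Cc4ccc(F)cc4)nn3)ccc12`, gives 12000 nM.
Compound 3, `O=c1ccoc2cc(OCc3cn(Cc4ccccc4Cl)nn3)ccc12`, gives only a limit of the assay, > 100000 nM.

Compounds 1 and 2 share the same core and differ by fluoro in place of chloro on an aromatic carbon; that change gave a 3.1-fold lower number from compound 1 to compound 2 (0.50 log units; beyond the scatter). Compound 3 differs from compound 1 by 2-chlorophenyl in place of 4-chlorophenyl on a saturated chain carbon bound to an aromatic nitrogen, and the outcome is an at least 2.6-fold higher number from compound 1 to compound 3 (0.42 log units; beyond the scatter). Measured against compound 2, the gap is an at least 8.3-fold higher number from compound 2 to compound 3 (0.92 log units; beyond the scatter). Both of these steps are open-ended, since compound 3 sits at the limit of this assay (the limit of > 100000 nM in this assay, at which 1 of the 3 values shown sits).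

Compound 4, `O=c1ccoc2cc(OCc3cn(Cc4ccccc4F)nn3)ccc12`, has not been measured. It differs from compound 3 by fluoro in place of chloro on an aromatic carbon. Within the data shown here, this is the same kind of change as the one from compound 1 to compound 2, but not the same: in the earlier pair the place was para to a large group, here it is ortho to a large group. Because the earlier step of a 3.1-fold lower number from compound 1 to compound 2 (0.50 log units; beyond the scatter) lowered the number by a modest amount, the same direction is expected for the step of an at least 1.6-fold lower number from compound 3 to compound 4 (0.22 log units; that floor lies within the scatter), with less certainty given the different place. Because compound 3 shows only a limit > 100000 nM, the starting point is itself unknown, and compound 4 may again reach only the limit. Compound 4 is therefore expected to give about 60000 nM in this assay, within 25000 nM to 150000 nM.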

Compound 4, half-maximal inhibitory concentration: > 100000 nM
Compound 4: no number, only a limit; the forecaster's own chance of this, stated with the estimate: 35%; at least 1.6-fold (0.22 log units) between middle value and limit.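

In this assay, the step from compound 3 to compound 4 cannot be read, and the same holds for any size of the fluoro for chloro change at this place, ortho to a large group, since both compounds give only a limit of the assay and not a number: the limit of > 100000 nM in this assay, at which 2 of the 4 values shown sit.

The two steps that can be read run from the compounds with the halogen on the 4-position of the phenyl group, an at least 8.3-fold higher number from compound 2 to compound 4 (0.92 log units; beyond the scatter) and an at least 2.6-fold higher number from compound 1 to compound 4 (0.42 log units; beyond the scatter), so 2-fluorophenyl, like 2-chlorophenyl, stands with a higher number than either 4-halophenyl compound. What this does not show is whether the lowering seen in a 3.1-fold lower number from compound 1 to compound 2 (0.50 log units; beyond the scatter) carries over to the 2-substituted compounds, because the data neither confirm nor rule out a shift hidden beyond the limit: the limit of > 100000 nM in this assay, at which 2 of the 4 values shown sit.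

The compounds shown leave open how far the numbers of compound 3 and compound 4 actually lie beyond the limit, and so whether fluoro and chloro differ at this place at all. They also leave open what a methoxy group, an amine or a carboxylic acid would give in place of the halogen on the phenyl ring.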